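Replacing the 4-(methylsulfonyl)piperazin-1-yl group with diethylamino

A few compounds are considered here, and "the series" means these few. Any claim that something is new, unique, unknown or untested is made for them only; others in the source may bear on it.

- compound 1 `CCN1C(=O)COc2c(CN3CCN(C(C)=O)CC3)cc(Nc3ncc(F)c(-c4ccc(F)cc4OC)n3)cc21` gives 6.9 ug/mL
- compound 2 `CCN1C(=O)COc2c(CN3CCN(S(C)(=O)=O)CC3)cc(Nc3ncc(F)c(-c4ccc(F)cc4OC)n3)cc21` gives 30.5 ug/mL

Compound 2 holds the higher of these two numbers in a physicochemical assay for solubility, read by HPLC, in phosphate buffer, measured as kinetic solubility, with a stated time of 24 h, at pH 7.4 (on this read-out higher numbers stand for higher solubility and lower numbers for lower solubility), and is the starting point here. Compound 3 `CCN(CC)Cc1cc(Nc2ncc(F)c(-c3ccc(F)cc3OC)n2)cc2c1OCC(=O)N2CC` differs from it in one place, and the change reads diethylamino in place of 4-(methylsulfonyl)piperazin-1-yl on a saturated chain carbon bound to an aromatic carbon in full. Diethylamino thus takes the place of 4-(methylsulfonyl)piperazin-1-yl on a saturated chain carbon bound to an aromatic carbon. Within the data shown here, only one measured step bears on this: a 4.4-fold higher number from compound 1 to compound 2 (0.65 log units; beyond the scatter) was modest but beyond the scatter, and it changed a group on the ring that now leaves. Among the measured compounds shown here, no measured compound lacks that ring, so the direction remains uncertain. A modest rise is expected, and the expected size is a 2.0-fold higher number from compound 2 to compound 3 (0.29 log units; within the scatter) as a rough estimate. Compound 3 is therefore expected at about 60 ug/mL with an estimated range of 12 ug/mL to 300 ug/mL in this assay when measured.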

Compound 3, solubility: 3.9 ug/mL
Estimate against measurement, compound 3: 15-fold (1.19 log units) above; the whole stated range lies above it.
By their numbers in this assay, from the lowest: compounds 3 and 1 (each within the scatter of the next); then compound 2.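

In this assay, putting diethylamino in place of 4-(methylsulfonyl)piperazin-1-yl on this saturated chain carbon gives a 7.8-fold lower number from compound 2 to compound 3 (0.89 log units; beyond the scatter) and shows that the group at this place can move the number beyond the scatter. Putting diethylamino in place of 4-acetylpiperazin-1-yl gives a 1.8-fold lower number from compound 1 to compound 3 (0.25 log units; within the scatter) and so leaves compound 1 and compound 3 indistinguishable, which means that the ring alone does not set the number: among these three compounds, only compound 2, with its methylsulfonyl group on that ring, stands apart. Nothing measured here accounts for this difference.

As far as these compounds go, what remains open is whether the methylsulfonyl group needs the ring at all, a question that a methylsulfonyl group carried on an open chain at this place could address. Morpholin-4-yl or an unsubstituted piperazin-1-yl at the same carbon would show how other rings compare.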